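The source may hold more compounds than are shown below. What is called first, only, known or untested is meant among the compounds shown, and "the series" means these compounds.

Compound 2 `Cn1c(CN2C[C@@H]3C(COc4ccc(Cl)cc4)[C@@H]3C2)nc2ccccc21` gives 26 nM in an in vitro assay on HEK293 cells with metabotropic glutamate receptor 2 (Rattus norvegicus) as the target, read by FLIPR, in the presence of a further agent that is not named here (a higher number here means that more compound is needed for the effect, a lower number that less compound is needed), the lowest of the two numbers shown; its nearest neighbour is compound 3 `Cn1c(CN2C[C@@H]3C(COc4ccc(C(F)(F)F)cc4)[C@@H]3C2)nc2ccccc21`, which gives 85 nM in this assay. Compound 1 `c1ccc(OCC2[C@H]3CN(Cc4nc5ccccc5s4)C[C@@H]23)cc1` reaches only a limit in this assay, > 10000 nM, which is the limit of > 10000 nM in this assay, at which 1 of the 3 values shown sits. For the measured compounds named here, the single measured step, a 3.3-fold higher number from compound 2 to compound 3 (0.51 log units; beyond the scatter), concerns the substituent on the aromatic ring rather than the ring itself. Compound 4 `Cn1c(CN2C[C@@H]3C(COc4ccc(Cl)nc4)[C@@H]3C2)nc2ccccc21` differs from compound 2 by 6-chloropyridin-3-yl in place of 4-chlorophenyl on an oxygen on a saturated carbon. Going by the values given here, no measured step covers this kind of change, so only the scale of the step from compound 2 to compound 3 offers guidance. The expected step is a 1.9-fold higher number from compound 2 to compound 4 (0.28 log units; within the scatter), small and possibly within the scatter. Compound 4 is thus estimated at 50 nM, with a range from 15 nM to 200 nM.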

Compound 4, half-maximal effective concentration: 511 nM
For compound 4 the middle estimate is 10-fold (1.01 log units) below the measured one; measured number outside the range, above it.
By their numbers in this assay, from the lowest: compound 2; then compound 3; then compound 4. At a limit, above all of these: compound 1.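

The change to 6-chloropyridin-3-yl gives a 20-fold higher number from compound 2 to compound 4 (1.29 log units; beyond the scatter) in this assay, so this place responds to the aromatic ring itself and not only to the substituent on it. For the compounds shown here, with the chlorine kept, the step is larger than the one for a change of substituent alone, which gives a 3.3-fold higher number from compound 2 to compound 3 (0.51 log units; beyond the scatter). Nothing shown here accounts for the size of this step.

From the compounds shown here alone, whether a pyrimidin-5-yl ring would behave like the pyridine remains open. So does whether a methoxy or a nitrile on the pyridine ring, in place of chloro, would bring the number back towards that of compound 2.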